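Oral bioavailability across three analogues of one shared core

A few compounds are considered here, and "the series" means these few. Any claim that something is new, unique, unknown or untested is made for them only; others in the source may bear on it.

Compound 1 `COc1ccc(C#CC(C)(C)N)cc1-c1[nH]nc2nc(Nc3ccc(F)cc3F)ccc12`, 95% in an in vivo ADME assay on the whole organism for pharmacokinetics, with Rattus norvegicus as the target; on this read-out lower numbers stand for lower oral bioavailability and higher numbers for higher oral bioavailability.
Compound 2 `COc1ccc(CCC(C)(C)N)cc1-c1[nH]nc2nc(Nc3ccc(F)cc3F)ccc12`, 20% in this assay.

Within the data shown here, compound 2 stands lowest of the two numbers measured so far; its nearest neighbour is compound 1, and the step of a number 75 percentage points lower from compound 1 to compound 2 (beyond the scatter) lies beyond the scatter. Compound 3 `COc1ccc(C(=O)NC2CCOCC2)cc1-c1[nH]nc2nc(Nc3ccc(F)cc3F)ccc12` has not yet been measured in this assay. It differs from compound 2 by (oxan-4-yl)carbamoyl in place of 3-amino-3-methylbutyl on an aromatic carbon, on an aromatic carbon of a six-membered aromatic ring of carbon only, meta to a large group and para to a methoxy group. Among the measured compounds shown here, the only measured step touching this place is a number 75 percentage points lower from compound 1 to compound 2 (beyond the scatter), which was large, so a sizeable step is plausible here as well, though its direction cannot be read from one step alone. The account therefore expects compound 3 to move upward, with a number 15 percentage points higher from compound 2 to compound 3 (beyond the scatter) as a tentative step. Compound 3 is estimated at 35%, within 8% to 80%.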

Compound 3, oral bioavailability: 22%
For compound 3 the middle estimate is 13 percentage points above the measured one; the measured number falls inside the stated range.
By their numbers in this assay, from the lowest: compounds 2 and 3 (each within the scatter of the next); then compound 1.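

At this position, para to a methoxy group, (oxan-4-yl)carbamoyl in place of 3-amino-3-methylbutyl gives a number 2 percentage points higher from compound 2 to compound 3 (within the scatter), so in this assay two groups that share little beyond their place on the ring cannot be told apart. Against 3-amino-3-methylbut-1-yn-1-yl, the same (oxan-4-yl)carbamoyl group gives a number 73 percentage points lower from compound 1 to compound 3 (beyond the scatter), which means that among the three groups shown the high number stays with 3-amino-3-methylbut-1-yn-1-yl alone. No measurement at hand accounts for this difference.

The compounds shown leave open whether the high number depends on the triple bond or on the amine of that chain. A 3-hydroxy-3-methylbut-1-yn-1-yl chain or a 3-amino-3-methylbut-1-en-1-yl chain at this place could fall with compound 1 or with compound 2 and compound 3.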